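The compounds below may be only part of what the source reports. "The series", "measured", "known", "first", "only" and "open" are said of these compounds alone.

Of the compounds shown here, three built on one shared core have been tested in a functional assay (Homo sapiens) for antiproliferative activity, read by resazurin assay, with a stated time of 48 h, tested at 10 uM; a lower number here means a weaker effect, a higher number a stronger effect of the compound at the concentration tested. Compound 1 `COc1cc(OC)c2c(=O)cc(-c3ccc(OC4CCN(C)CC4)cc3)oc2c1` gives 49%, compound 2 `COc1cc(OC)c2c(=O)cc(-c3ccc(OC4CCNCC4)cc3)oc2c1` gives 21%, and compound 3 `COc1cc(OC)c2c(=O)cc(-c3ccc(OCCN)cc3)oc2c1` gives 35%. Compound 3 therefore stands second highest of the three numbers: its nearest neighbour is compound 1, with a number 14 percentage points lower from compound 1 to compound 3 (beyond the scatter), and its furthest is compound 2, with a number 14 percentage points higher from compound 2 to compound 3 (beyond the scatter).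

Compound 4 `COc1cc(OC)c2c(=O)cc(-c3ccc(OCC(O)CN4CCCC4)cc3)oc2c1` is the next candidate. It differs from compound 3 by 1-hydroxy-2-(pyrrolidin-1-yl)ethyl in place of aminomethyl on a saturated chain carbon bound to an oxygen on an aromatic ring. For the measured compounds named here, two measured steps bear on this change. The step of a number 28 percentage points lower from compound 1 to compound 2 (beyond the scatter) shows that losing the methyl costs a modest amount, and the step of a number 14 percentage points higher from compound 2 to compound 3 (beyond the scatter) shows that opening that ring to a 2-aminoethyl chain recovers part of it. Compound 4 returns to a nitrogen that sits in a ring and carries no hydrogen, the arrangement found in compound 1, which gives the highest number of the three. Going by the values given here, a modest rise beyond the scatter is therefore expected, a number 13 percentage points higher from compound 3 to compound 4 (beyond the scatter), though the added hydroxy group has no precedent among the measured compounds. Compound 4 is estimated at 48%, within a range from 30% to 65%.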

Compound 4, a percentage reported as inhibition, at one concentration (the size of the read-out at that concentration, not a potency): 37%
Compound 4: middle estimate off by 11 percentage points, on the high side; low and high end bracket the measured number.
By their numbers in this assay, from the lowest: compound 2; then compounds 3 and 4 (each within the scatter of the next); then compound 1.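

In this assay, the step to the larger group gives a number 2 percentage points higher from compound 3 to compound 4 (within the scatter), so on this saturated chain carbon, 8 heavy atoms including a five-membered ring and a hydroxy group can stand in place of the 2 heavy atoms of aminomethyl without a change that can be told from the scatter. The nitrogen in a ring with no hydrogen on it does not by itself bring the read-out level with the 1-methylpiperidin-4-yl group, as the comparison shows a number 12 percentage points lower from compound 1 to compound 4 (beyond the scatter), while the comparison with the piperidin-4-yl group shows a number 16 percentage points higher from compound 2 to compound 4 (beyond the scatter). Nothing measured for these compounds explains these differences.

The hydroxy group and the pyrrolidine ring enter together, so the part each plays cannot be separated here, and a plain 3-(pyrrolidin-1-yl)propyl chain without the hydroxy group would be the direct comparison. On these data alone, it also remains open how a morpholine ring or a dimethylamino group at the end of the same chain would read in this assay, and whether a longer chain would change the picture.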